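Isopropyl gives way to but-3-yn-1-yl on the shared core

The source may report more compounds than this note shows. Statements on the series, on what has been measured and on what is new or still open speak of the compounds shown alone.

In a functional assay on HL-60 cells (Homo sapiens) for inhibition, read by MTT assay, with a stated time of 72 h (a higher number here means a weaker inhibitor, a lower number a stronger inhibitor), compound 1 (`O=C1C=C[C@@H](OC2CCCCC2)O[C@@H]1CO`) gives 13300 nM and compound 2 (`CC(C)O[C@@H]1C=CC(=O)[C@@H](CO)O1`) gives 9700 nM as its reading. These two numbers lie within the usual scatter of each other, so compound 2 cannot be told apart from compound 1 on the data so far. Compound 3 (`C#CCCO[C@@H]1C=CC(=O)[C@@H](CO)O1`) has not yet been measured. It keeps the core of compound 2 but carries but-3-yn-1-yl in place of isopropyl on an oxygen on a saturated carbon. For the measured compounds named here, no step between measured compounds shows what such a swap does. With compound 2 at 9700 nM as the starting point, no step beyond the scatter is expected in this assay in either direction. That amounts to an expected 1.1-fold lower number from compound 2 to compound 3 (0.03 log units; within the scatter) and no more. Compound 3 is estimated at 9000 nM with a range from 3500 nM to 22000 nM for now.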

Compound 3, half-maximal inhibitory concentration: 2500 nM
The estimate for compound 3 lay 3.6-fold (0.56 log units) above the measured number; the whole stated range lies above it.
By their numbers in this assay, from the lowest: compound 3; then compounds 2 and 1 (each within the scatter of the next).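

For the compounds shown here, the step to but-3-yn-1-yl is the first here to pass the scatter: in this assay there is a 3.9-fold lower number from compound 2 to compound 3 (0.59 log units; beyond the scatter), so the group on this oxygen on a saturated carbon can shift the reading, something the values of compound 1 and compound 2, within the scatter of each other, gave no sign of. The change brings in a triple bond outside aromatic rings and a chain of four carbons, while neither group has hydrogen-bond donors or acceptors or a net charge. Nothing available explains why this swap lowers the number.

From the compounds shown here alone, it remains open whether the triple bond or the chain length goes with the lower number, and a plain butyl group on this oxygen would separate the two. Going by these compounds, whether a longer alkynyl chain or an amine at the chain end would hold, extend or lose the step also remains open.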